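The compounds below may be only part of what the source reports. "The series", "measured", "known", "first", "only" and "open" are said of these compounds alone.

Compound 1 `COc1ccc(C[S+]([O-])c2ncccc2C(=O)Nc2ccncc2)c(OC)c1` and compound 2 `COc1cccc(OC)c1C[S+]([O-])c1ncccc1C(=O)Nc1ccncc1` share one core and differ in where their methoxy groups sit. Going by the values given here, in an ADME assay (a lower number here means that the compound disappears faster, a higher number that the compound lasts longer), compound 2 gives 0.66 h, the only true number so far. Compound 1 gives < 0.02 h, which is a limit of the assay and not a number. Compound 3 `COc1cc(OC)c(C[S+]([O-])c2ncccc2C(=O)Nc2ccncc2)c(OC)c1` has methoxy in place of hydrogen on an aromatic carbon of compound 2, meta to two methoxy groups and para to a large group: methoxy in place of hydrogen on an aromatic carbon. Among the compounds with values here, no measured step isolates this change. Compound 1 also has a methoxy para to a large group, and its limit of < 0.02 h suggests that a clear fall beyond the scatter in this assay can be expected. The estimated change is a 4.4-fold lower number from compound 2 to compound 3 (0.64 log units; beyond the scatter). For compound 3 the expected half-life is 0.15 h, with an estimated range of 0.03 h to 0.6 h.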

Compound 3, half-life: < 0.02 h
Compound 3 ended at the assay's limit; the forecaster's own chance of this, stated with the estimate: 25%; middle value at least 7.5-fold (0.87 log units) away from the limit.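

In this assay, methoxy in place of hydrogen on this aromatic carbon, para to a large group, gives an at least 33-fold lower number from compound 2 to compound 3 (1.51 log units; beyond the scatter). Going by these compounds alone, this is the first measured step at this position, and it shows that one added methoxy here, with the two methoxy groups of compound 2 still in place, is enough to take the half-life from a readable number to a limit of the assay. The step from compound 1 to compound 3 cannot be read, and the step from compound 2 gives only a minimum size, as compound 3 sits at a limit: the limit of < 0.02 h in this assay, at which 2 of the 3 values shown sit.

From the compounds shown here alone, the real half-lives of compound 1 and compound 3 remain unknown. Going by these compounds, it also remains open how the half-life would respond to a fluorine, a methyl or an amine at this position.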